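A few compounds are considered here, and "the series" means these few. Any claim that something is new, unique, unknown or untested is made for them only; others in the source may bear on it.

Compound 1 `COc1ccc(F)cc1CNCCCNc1ccnc2cc(CCC(C)C)ccc12` gives 890 nM in an ADME assay on HepG2 cells (Homo sapiens) for cytotoxicity, read by luminescence, CellTiter-Glo and ATP content, with a stated time of 72 h; a lower number here means that less compound is needed, a higher number that more compound is needed for the effect.
Compound 2 `COc1ccc(F)cc1CNCCCNc1ccnc2cc(CC(C)C)ccc12` gives 2900 nM in this assay.
Compound 3 `COc1ccc(F)cc1CNCCCNc1ccnc2cc(-c3cccc4ccccc34)ccc12` has not yet been measured in this assay.

Among the measured compounds shown here, compound 2 has the higher of the two numbers measured so far. For the measured compounds named here, the only step seen, a 3.3-fold higher number from compound 1 to compound 2 (0.51 log units; beyond the scatter), shows that exchanging this group moved the number beyond the scatter, with the isopentyl compound giving the lower number. Compound 3 differs from compound 2 by naphthalen-1-yl in place of isobutyl on an aromatic carbon. Going by the values given here, no measured step involves an aromatic group of this kind, so that single step is only a loose guide. Compound 3 is therefore expected to give a moderately lower number, a 2.9-fold lower number from compound 2 to compound 3 (0.46 log units; beyond the scatter), with an estimate of 1000 nM and a range from 300 nM to 4000 nM.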

Compound 3, half-maximal effective concentration: 16000 nM
Compound 3: middle estimate off by 16-fold (1.20 log units), on the low side, and the stated range ends below it.
By their numbers in this assay, from the lowest: compound 1; then compound 2; then compound 3.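

In this assay, among the compounds shown here, naphthalen-1-yl at this place on the shared core gives the highest number so far, with a 5.5-fold higher number from compound 2 to compound 3 (0.74 log units; beyond the scatter) and an 18-fold higher number from compound 1 to compound 3 (1.25 log units; beyond the scatter). Between the two chains, the longer isopentyl gave the lower number, but the larger naphthalen-1-yl does not continue that trend, so group size alone does not order these three compounds. No available evidence explains this result. As far as these compounds go, whether phenyl or a chain ending in an amine would fall nearer the chains or nearer naphthalen-1-yl remains open, so the rise cannot yet be assigned to aromatic groups in general.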